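Swapping Methylsulfonyl for Cyano on the Chloro Analogue

The source may hold more compounds than are shown below. What is called first, only, known or untested is meant among the compounds shown, and "the series" means these compounds.

Compound 1, `N#Cc1ccc(-c2cnc3[nH]cc(-c4nnc(-c5ccc(F)cc5)o4)c(=O)c3c2)cc1`, in a functional assay on HCT-116 cells (Homo sapiens) for positive allosteric modulation, read by MTT assay, with stated times of 24 h and 48 h, tested at 2.5 uM (on this read-out higher numbers stand for more inhibition of growth at the one concentration tested and lower numbers for less inhibition of growth), gives 25.6%.
Compound 2, `CS(=O)(=O)c1ccc(-c2cnc3[nH]cc(-c4nnc(-c5ccc(F)cc5)o4)c(=O)c3c2)cc1`, in this assay gives 39.5%.
Compound 3, `CS(=O)(=O)c1ccc(-c2cnc3[nH]cc(-c4nnc(-c5ccc(Cl)cc5)o4)c(=O)c3c2)cc1`, in this assay gives 24.9%.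

Compound 3 sits at the low end of these three numbers. Its number and that of compound 1 differ by less than the usual scatter, so the two cannot be told apart; against compound 2 the difference is real, the step of a number 14.6 percentage points lower from compound 2 to compound 3 (beyond the scatter) lying beyond the scatter.

Compound 4, `N#Cc1ccc(-c2cnc3[nH]cc(-c4nnc(-c5ccc(Cl)cc5)o4)c(=O)c3c2)cc1`, differs from compound 3 in one place: cyano in place of methylsulfonyl on an aromatic carbon. The same swap has been measured once already, in the opposite direction and on the fluoro-bearing pair, where the step of a number 13.9 percentage points higher from compound 1 to compound 2 (beyond the scatter) was seen. Running that swap backwards on the chloro-bearing pair, a drop of similar size is expected, a number 12.9 percentage points lower from compound 3 to compound 4 (beyond the scatter). Going by the values given here, only one measured step speaks to this, so the range is kept wide.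

For compound 4 in this assay the expected value is 12%, with a range from 0% to 26%.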

Compound 4, percent growth inhibition at one concentration: 35.4%
Compound 4: middle estimate off by 23.4 percentage points, on the low side; measured number outside the range, above it.
By their numbers in this assay, from the lowest: compounds 3, 1, 4 and 2 (each within the scatter of the next, the first and the last beyond it).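

The methylsulfonyl-to-cyano swap has no fixed direction at this place in this assay: on the chloro-bearing pair the step is a number 10.5 percentage points higher from compound 3 to compound 4 (beyond the scatter) and cyano carries the higher number, while on the fluoro-bearing pair methylsulfonyl carried it: the same change on two cores in this assay, a number 13.9 percentage points higher (beyond the scatter) from compound 1 to compound 2 and a number 10.5 percentage points lower (beyond the scatter) from compound 4 to compound 3, 24.4 percentage points apart, beyond the scatter of two such steps.
The halogen change also depends on its partner, with a number 14.6 percentage points lower from compound 2 to compound 3 (beyond the scatter) on the methylsulfonyl pair and a number 9.8 percentage points higher from compound 1 to compound 4 (within the scatter) on the cyano pair: the same change on two cores in this assay, a number 14.6 percentage points lower (beyond the scatter) from compound 2 to compound 3 and a number 9.8 percentage points higher (within the scatter) from compound 1 to compound 4, 24.4 percentage points apart, beyond the scatter of two such steps.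
Across these four compounds the two changes therefore do not act independently, and the effect of one cannot be added to the effect of the other.

As far as these compounds go, it remains open whether this interplay persists with bromo or methoxy in place of the halogen, or with an amine or a carboxylic acid in place of cyano. All four numbers also come from a single concentration, so the order of these compounds across a range of concentrations is unknown.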